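Methoxy to fluoro on the phenyl ring of compound 2

The compounds below may be only part of what the source reports. "The series", "measured", "known", "first", "only" and "open" are said of these compounds alone.

Measured so far:
compound 1 `COc1ccc(-c2cn3ccnc3c(-c3ccc4ncn(C5CCCCC5)c4c3)n2)cc1` gives -26.3%
compound 2 `COc1ccccc1-c1cn2ccnc2c(-c2ccc3ncn(C4CCCCC4)c3c2)n1` gives 35%

In a functional assay on SNB-75 cells (Homo sapiens) for inhibition, read by sulforhodamine B assay, with a stated time of 48 h, tested at 10 uM (a lower number here means less inhibition, a higher number more inhibition at the concentration tested (going by the name of the read-out)), compound 2 stands highest of the two numbers, its nearest neighbour being compound 1, which lies a long way lower. For the measured compounds named here, the only measured step, a number 61.3 percentage points higher from compound 1 to compound 2 (beyond the scatter), is large and beyond the scatter, but it concerns where the methoxy sits on the phenyl ring, not what the group is.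

Compound 3 `Fc1ccccc1-c1cn2ccnc2c(-c2ccc3ncn(C4CCCCC4)c3c2)n1` differs from compound 2 by fluoro in place of methoxy on an aromatic carbon. Going by the values given here, no measured step covers an exchange of this kind, so the one step available bears on it only indirectly: it shows that the ring bearing the 2-methoxyphenyl substituent is sensitive to change at that place. Some loss is therefore expected, of about a number 15 percentage points lower from compound 2 to compound 3 (beyond the scatter), with wide uncertainty. Compound 3 is estimated at 20%, within a range from -20% to 55%.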

Compound 3, a percentage reported as inhibition, at one concentration (the size of the read-out at that concentration, not a potency): 29.7%
Beside the measured number, compound 3's estimate is 9.7 percentage points below it; the measured number falls inside the stated range.
By their numbers in this assay, from the lowest: compound 1; then compounds 3 and 2 (each within the scatter of the next).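

In this assay, the step of a number 5.3 percentage points lower from compound 2 to compound 3 (within the scatter) shows that the number stays level at this place, ortho to a large group, on the exchange of methoxy for fluoro, even though the heavy atoms go from 2 to 1 and the hydrogen-bond acceptors from 1 to 0. The step of a number 56 percentage points higher from compound 1 to compound 3 (beyond the scatter) shows that the large gap first seen with compound 2 also holds with a second, different group at this place, though this step changes both the group and where it sits. The data shown offer no explanation for either step.

Still open is whether this place needs a substituent at all, as the shown compounds offer no comparison with an unsubstituted phenyl ring. Going by these compounds, it is also open whether an amine, a carboxylic acid or a longer chain such as butoxy would fit here as well as methoxy and fluoro do.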